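The source may hold more compounds than are shown below. What is called first, only, known or untested is meant among the compounds shown, and "the series" means these compounds.

Measured so far in a functional assay on the whole organism (6C3HED cells, Mus musculus) for inhibition, at a dose of 150 mg/kg by the oral route; a higher number here means more inhibition at the dose given (going by the name of the read-out), a lower number less inhibition:
compound 1 `O=C(Nc1ccc(Cl)cc1)NS(=O)(=O)c1cccs1` gives 16%
compound 2 `CSc1ccc(S(=O)(=O)NC(=O)Nc2ccc(Cl)cc2)s1` gives 29%
compound 3 `CCc1ccc(S(=O)(=O)NC(=O)Nc2ccc(Cl)cc2)o1` gives 57%

Compound 3 stands highest of the three, with compound 2 nearest and compound 1 furthest. Compound 4 `Cc1ccsc1S(=O)(=O)NC(=O)Nc1ccc(Cl)cc1` is not yet measured; its change from compound 3 is 3-methylthiophen-2-yl in place of 5-ethylfuran-2-yl on a sulfonyl sulfur. Among the measured compounds shown here, two steps bear on this: a number 41 percentage points higher from compound 1 to compound 3 (beyond the scatter) and a number 28 percentage points higher from compound 2 to compound 3 (beyond the scatter), both large gains on moving to the 5-ethylfuran-2-yl group. Reversing that move to a thiophene bearing a methyl is expected to give back much of the gain, so a drop in this assay is expected, of about a number 29 percentage points lower from compound 3 to compound 4 (beyond the scatter). Compound 4 is therefore estimated at 28%, in the range 10% to 50%.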

Compound 4, a percentage reported as inhibition, in the whole organism at one dose (the size of the read-out at that dose, not a potency): 17%
The estimate for compound 4 lay 11 percentage points above the measured number, within the range that was stated.
By their numbers in this assay, from the lowest: compounds 1 and 4 (each within the scatter of the next); then compound 2; then compound 3.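

In this assay a methyl on this thiophene adds nothing beyond the scatter, a change of a number 1 percentage points higher from compound 1 to compound 4 (within the scatter) and so the gain does not follow from any small alkyl group on the ring. 3-Methylthiophen-2-yl also falls short of both better sulfonyl substituents, with a number 12 percentage points lower from compound 2 to compound 4 (beyond the scatter) and a number 40 percentage points lower from compound 3 to compound 4 (beyond the scatter) in the step to the ethylfuran. Nothing measured here explains these steps.

Still open, as far as these compounds go, is whether the furan ring or the ethyl group carries the advantage of compound 3. 5-Ethylthiophen-2-yl or unsubstituted furan-2-yl on the sulfonyl sulfur would separate the two.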